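Moving the Methoxy Group Around the Sulfonyl Ring

The compounds below may be only part of what the source reports. "The series", "measured", "known", "first", "only" and "open" are said of these compounds alone.

Of the compounds shown here, three sharing one core have been tested in a functional assay (Cavia porcellus) with sulfonylurea receptors; K-ATP channels (Homo sapiens) as the target; a higher number here means a weaker inhibitor, a lower number a stronger inhibitor. Compound 1 `CC(O)(C(=O)Nc1ccc(S(=O)(=O)c2ccccc2C#N)cc1)C(F)(F)F` gives 1100 nM. Compound 2 `CC(O)(C(=O)Nc1ccc(S(=O)(=O)c2ccc(C#N)cc2)cc1)C(F)(F)F` reaches only a limit of the assay, recorded as > 30000 nM. Compound 3 `COc1ccccc1S(=O)(=O)c1ccc(NC(=O)C(C)(O)C(F)(F)F)cc1` gives 1600 nM, which is the higher of the two plain numbers, although the gap to compound 1 is small: a 1.5-fold higher number from compound 1 to compound 3 (0.16 log units; within the scatter), so the two cannot be told apart with confidence. By contrast, an at least 27-fold higher number from compound 1 to compound 2 (1.43 log units; beyond the scatter) is large, and an at least 18-fold lower number from compound 2 to compound 3 (1.27 log units; beyond the scatter) is large as well.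

Compound 4 `COc1ccc(S(=O)(=O)c2ccc(NC(=O)C(C)(O)C(F)(F)F)cc2)cc1` differs from compound 3 in one place: 4-methoxyphenyl in place of 2-methoxyphenyl on a sulfonyl sulfur. The measured step that bears directly on this is an at least 27-fold higher number from compound 1 to compound 2 (1.43 log units; beyond the scatter), the same kind of move of a substituent within the phenyl on the sulfonyl sulfur, there with a nitrile, here with a methoxy. That step was big and ended at the assay limit, as noted by the limit of > 30000 nM in this assay, at which 1 of the 3 values shown sits. The expectation for compound 4 is therefore a large weakening in this assay, a 19-fold higher number from compound 3 to compound 4 (1.27 log units; beyond the scatter), with a real chance that only a limit is reported. Compound 4 is estimated at 30000 nM, within a range from 8000 nM to 100000 nM.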

Compound 4, half-maximal inhibitory concentration: > 30000 nM
Compound 4: a limit, no number; the forecaster's own chance of this, stated with the estimate: 60%; the middle value sits exactly at the limit.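

With the methoxy group too, 4-methoxyphenyl in place of 2-methoxyphenyl on the sulfonyl sulfur brings a large weakening in this assay, an at least 18-fold higher number from compound 3 to compound 4 (1.27 log units; beyond the scatter), so among the compounds shown this loss is no longer seen with the nitrile alone. Compound 4 also stands far from the compound that carries 2-cyanophenyl on the sulfonyl sulfur, an at least 27-fold higher number from compound 1 to compound 4 (1.43 log units; beyond the scatter), which leaves both compounds with a 2-substituted ring on the strong side of the set and both with a 4-substituted ring on the weak side. The result for compound 4 is a limit of the assay and not a number, and this limit now recurs among the compounds shown: the limit of > 30000 nM in this assay, at which 2 of the 4 values shown sit.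

Compound 2 and compound 4 both end at limits, so the step between them cannot be read, and nothing shows whether nitrile or methoxy is the better group on the 4-substituted ring. On these data alone, it also stays open whether an amine or a carboxylic acid, in place of the methoxy of compound 3, would keep the number in the range of compound 1 and compound 3.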